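Fluoro to trifluoromethyl on the benzyl group

A few compounds are considered here, and "the series" means these few. Any claim that something is new, unique, unknown or untested is made for them only; others in the source may bear on it.

Compound 1 `Cc1cc(Nc2cc(-c3ccccc3)[nH]n2)n2nc(SCc3ccc(Cl)cc3)nc2n1` gives 6710 nM
Compound 2 `Cc1cc(Nc2ccn(Cc3ccc(F)cc3)n2)n2nc(SCc3ccc(Br)cc3)nc2n1` gives 19400 nM
Compound 3 `Cc1cc(Nc2cc(-c3ccc(Cl)cc3)[nH]n2)n2nc(SCc3ccc(Br)cc3)nc2n1` gives 4920 nM

These values come from a functional assay on PC-9 cells (Homo sapiens) for inhibition, read by MTT assay, with a stated time of 72 h (a lower number here means a stronger inhibitor, a higher number a weaker inhibitor), and compound 2 stands highest of the three at 19400 nM as the weakest inhibitor, with its gaps to compound 1 and compound 3 both beyond the scatter. Compound 4 `Cc1cc(Nc2ccn(Cc3ccc(C(F)(F)F)cc3)n2)n2nc(SCc3ccc(Br)cc3)nc2n1` has not yet been measured. It differs from compound 2 by trifluoromethyl in place of fluoro on an aromatic carbon with trifluoromethyl in place of fluoro on an aromatic carbon, para to a large group. Going by the values given here, no measured pair shows this change. A step within the scatter is expected, with a slight lean toward a lower number. An estimated 1.3-fold lower number from compound 2 to compound 4 (0.11 log units; within the scatter) is all that is expected. Compound 4 is expected at 15000 nM within an estimated range of 6500 nM to 35000 nM once tested.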

Compound 4, half-maximal inhibitory concentration: 5580 nM
Compound 4: the middle estimate sits 2.7-fold (0.43 log units) above what was measured; measured number outside the range, below it.
By their numbers in this assay, from the lowest: compounds 3, 4 and 1 (each within the scatter of the next); then compound 2.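

In this assay, going by these compounds alone, the exchange of 4-fluorobenzyl for 4-(trifluoromethyl)benzyl gives a 3.5-fold lower number from compound 2 to compound 4 (0.54 log units; beyond the scatter) and is the first single-place comparison available. It shows that the group on this aromatic carbon affects the read-out, and that the larger trifluoromethyl is accepted here with a lower number. No measurement shown accounts for the step.

The compounds shown leave open how a methoxy group, an amine or a carboxylic acid on this carbon would read. They also leave open whether the same exchange would act alike with another group in place of the 4-bromobenzyl thioether.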